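A few compounds are considered here, and "the series" means these few. Any claim that something is new, unique, unknown or untested is made for them only; others in the source may bear on it.

Measured in a functional assay on SW-620 cells (Homo sapiens) for cytotoxicity, read by sulforhodamine B assay, with a stated time of 48 h; a lower number here means a stronger inhibitor, a higher number a weaker inhibitor:
- compound 1 `C[C@H]1CC[C@@H]2[C@@H](OC(=O)[C@]23CC(c2ccc([N+](=O)[O-])cc2)=NO3)[C@]2(C)C(=O)C=C[C@@]12O`: 9000 nM
- compound 2 `COc1ccc(C2=NO[C@]3(C2)C(=O)O[C@@H]2[C@H]3CC[C@H](C)[C@]3(O)C=CC(=O)[C@@]23C)cc1OC`: 86000 nM
- compound 3 `C[C@H]1CC[C@@H]2[C@@H](OC(=O)[C@]23CC(c2ccccc2F)=NO3)[C@]2(C)C(=O)C=C[C@@]12O`: 11000 nM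

Two steps place the 2-fluorophenyl member in the lower pair of the three numbers: a 1.2-fold higher number from compound 1 to compound 3 (0.09 log units; within the scatter), and a 7.8-fold lower number from compound 2 to compound 3 (0.89 log units; beyond the scatter).

Next is compound 4 `Cc1ccc(C2=NO[C@]3(C2)C(=O)O[C@@H]2[C@H]3CC[C@H](C)[C@]3(O)C=CC(=O)[C@@]23C)cc1`, with 4-methylphenyl in place of 2-fluorophenyl on a carbon with a double bond to nitrogen.

The bearing evidence is the set of changes at this same place. One is a 9.6-fold higher number from compound 1 to compound 2 (0.98 log units; beyond the scatter). The others are the two steps above. Among the measured compounds shown here, no measured compound carries a methyl group, so only a small move is expected in this assay, tilted upward since compound 2 reached 86000 nM. The estimated step is a 1.6-fold higher number from compound 3 to compound 4 (0.21 log units; within the scatter). For compound 4 the expected value is 18000 nM, with an estimated range of 6000 nM to 60000 nM.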

Compound 4, half-maximal inhibitory concentration: 2500 nM
Compound 4: the middle estimate sits 7.2-fold (0.86 log units) above what was measured; measured number outside the range, below it.
By their numbers in this assay, from the lowest: compound 4; then compounds 1 and 3 (each within the scatter of the next); then compound 2.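

In this assay, among the compounds shown here, 4-methylphenyl is the first group at this place to separate from the others on the low side, with a 4.4-fold lower number from compound 3 to compound 4 (0.64 log units; beyond the scatter) and a 3.6-fold lower number from compound 1 to compound 4 (0.56 log units; beyond the scatter) both beyond the scatter. The spread among groups on this carbon also widens to a 34-fold lower number from compound 2 to compound 4 (1.54 log units; beyond the scatter) at the top end. No measurement on hand accounts for these differences.

Still open, from the compounds shown here alone, is whether a longer alkyl chain in place of the methyl would extend the drop. An amine or a carboxylic acid on the phenyl ring is equally unplaced in this series.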